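The source may report more compounds than this note shows. Statements on the series, on what has been measured and on what is new or still open speak of the compounds shown alone.

Working notes on the series. Three compounds have a number in a functional assay on NCI-H1975 cells (Homo sapiens) for antiproliferative activity, read by MTT assay, with a stated time of 72 h (a lower number here means a stronger inhibitor, a higher number a weaker inhibitor), so far. Compound 3 `C=CC(=O)Nc1cc(Nc2nccc(-c3cn(C)c4ccc(F)cc34)n2)c(OC)cc1N(C)CCN(C)C` gives 254 nM and stands lowest of the three. Compound 2 `C=C(Cl)C(=O)Nc1cc(Nc2nc(C)cc(-c3cn(C)c4ccccc34)n2)c(OC)cc1N(C)CCN(C)C` gives 2230 nM, and compound 1 `COc1cc(N(C)CCN(C)C)c(NC(=O)C=C(C)C)cc1Nc1nccc(-c2cn(C)c3ccccc23)n1` gives 5610 nM; both of these differ from compound 3 in more than one place, so their gaps to compound 3, which are both beyond the usual scatter, cannot be assigned to any single change. It is only noted that compound 1, whose acyl group carries two methyls on the double bond, sits highest of the three.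

Compound 4 `COc1cc(N(C)CCN(C)C)c(NC(=O)/C=C\C(C)C)cc1Nc1nccc(-c2cn(C)c3ccc(F)cc23)n1` is the next compound awaiting a number in this assay. It differs from compound 3 in one place: 3-methylbut-1-en-1-yl in place of vinyl on a carbonyl carbon. Among the compounds with values here, no pair of measured compounds differs in exactly this way, so the step has no direct precedent. On what the three numbers show, the expectation is that compound 4 moves upward from compound 3, by a step of a 5.9-fold higher number from compound 3 to compound 4 (0.77 log units; beyond the scatter), beyond the scatter but short of the gap to compound 1. The estimate for compound 4 in this assay is 1500 nM, with a range from 500 nM to 5000 nM.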

Compound 4, half-maximal inhibitory concentration: 7360 nM
Beside the measured number, compound 4's estimate is 4.9-fold (0.69 log units) below it; measured number above the stated range.
By their numbers in this assay, from the lowest: compound 3; then compound 2; then compounds 1 and 4 (each within the scatter of the next).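

In this assay, within the data shown here, replacing vinyl with 3-methylbut-1-en-1-yl on the carbonyl carbon, the only difference within the pair, gives a 29-fold higher number from compound 3 to compound 4 (1.46 log units; beyond the scatter), a large step and the first that can be read at a single place. The earlier gaps each involved more than one change, whereas this higher number belongs to this one position, where the group grows from 2 to 5 heavy atoms, all carbon, and the double bond outside aromatic rings, the hydrogen-bond donor and acceptor counts and the net charge stay as they were. No measurement available here bears on what lies behind the step.

With a single pair, the effect of the longer branched chain cannot be separated from that of the particular double-bond arrangement in compound 4. Going by these compounds, it also remains open how this position responds to a shorter group such as prop-1-en-1-yl or to a chain ending in a dimethylamine, and whether the step would be of similar size on a core other than that of compound 3.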